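The source may report more compounds than this note shows. Statements on the series, on what has been measured and on what is new or still open speak of the compounds shown alone.

Measured so far:
compound 1 `O=C(c1ccccn1)N1CCC(NS(=O)(=O)c2cc(S(=O)(=O)c3ccccc3)ccc2C(F)(F)F)CC1` — 230 nM
compound 2 `O=C(O)c1cccc(S(=O)(=O)N2CCC(NS(=O)(=O)c3cc(S(=O)(=O)c4ccccc4)ccc3C(F)(F)F)CC2)c1` — 190 nM

Going by the values given here, of the two numbers in an assay on U2OS cells for inhibition of secreted frizzled-related protein 1 (Homo sapiens), read by a luciferase reporter, with a stated time of 18 h (a lower number here means that less compound is needed, a higher number that more compound is needed for the effect), compound 1 has the higher one; its only neighbour is compound 2, and the step of a 1.2-fold lower number from compound 1 to compound 2 (0.08 log units; within the scatter) stays within the scatter. Compound 3 `CC(C)(C)OC(=O)N1CCC[C@@H]1C(=O)N1CCC(NS(=O)(=O)c2cc(S(=O)(=O)c3ccccc3)ccc2C(F)(F)F)CC1` carries the change (1-(tert-butoxycarbonyl)pyrrolidin-2-yl in place of pyridin-2-yl on a carbonyl carbon). Among the compounds with values here, the one measured step at this position, a 1.2-fold lower number from compound 1 to compound 2 (0.08 log units; within the scatter), exchanged the whole group on the amine nitrogen and moved the number barely at all, so no shift beyond the scatter is expected for compound 3 in this assay; the expected step is a 1.1-fold higher number from compound 1 to compound 3 (0.04 log units; within the scatter). Compound 3 is therefore estimated at 250 nM, with a range of 100 nM to 650 nM.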

Compound 3, half-maximal effective concentration: 210 nM
For compound 3 the middle estimate is 1.2-fold (0.08 log units) above the measured one, and the stated range covers the measured number.
By their numbers in this assay, from the lowest: compounds 2, 3 and 1 (each within the scatter of the next).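

Keeping the carbonyl on the ring nitrogen, the exchange of pyridin-2-yl for 1-(tert-butoxycarbonyl)pyrrolidin-2-yl gives a 1.1-fold lower number from compound 1 to compound 3 (0.04 log units; within the scatter) in this assay. The earlier step exchanged the whole group on the amine nitrogen; this one shows that, with the carbonyl retained, a larger non-aromatic ring with a defined stereocentre also stays within the scatter. No available data explain this result.
Open, on these data alone, is whether the free pyrrolidine amine, without tert-butoxycarbonyl, stays within the scatter. As far as these compounds go, the opposite stereocentre at the pyrrolidine carbon is also open.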